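From Thiophen-2-yl to Thiophen-3-yl: Compound 1 to Compound 4

This account rests on a few compounds, and the source may have more. Where it says the series, first, only, none or still open, it means among the compounds named here.

Measured compounds:
Compound 1 `C=C(Br)C(=O)Nc1ccc2c(c1)/C(=C/c1cccs1)C(=O)N2`: 35 nM
Compound 2 `C=C(Br)C(=O)Nc1ccc2c(c1)CC(=O)N2`: 220 nM
Compound 3 `C=C(Br)C(=O)Nc1ccc2c(c1)/C(=C\c1sccc1C)C(=O)N2`: 0.9 nM

In a functional assay on CCRF-CEM cells (Homo sapiens) for antiproliferative activity, read by MTT assay, with a stated time of 72 h (on this read-out lower numbers stand for stronger inhibition and higher numbers for weaker inhibition), compound 1 holds the second highest of the three numbers. Compound 2 gives a clearly higher number, beyond the scatter, while compound 3 gives a far lower number, also beyond the scatter, so compound 1 sits between them.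

Compound 4 `C=C(Br)C(=O)Nc1ccc2c(c1)/C(=C/c1ccsc1)C(=O)N2` has not yet been measured. It keeps every atom of compound 1 and differs in one place: thiophen-3-yl in place of thiophen-2-yl on a double-bonded chain carbon bound to a double-bonded ring carbon. Going by the values given here, no measured pair shows this exact change, so the step from compound 1 to compound 4 is expected to be small, a 1.6-fold higher number from compound 1 to compound 4 (0.20 log units; within the scatter), a slight rise in the number that may stay within the scatter. Compound 4 is therefore estimated at 55 nM, with a range from 15 nM to 200 nM.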

Compound 4, half-maximal inhibitory concentration: 4 nM
Estimate against measurement, compound 4: 14-fold (1.14 log units) above; the measured number lies below the stated range.
By their numbers in this assay, from the lowest: compound 3; then compound 4; then compound 1; then compound 2.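

Thiophen-3-yl and thiophen-2-yl have the same atoms and the same counts, yet swapping one for the other gives an 8.8-fold lower number from compound 1 to compound 4 (0.94 log units; beyond the scatter) in this assay. At this place, on a double-bonded chain carbon bound to a double-bonded ring carbon, the way the thiophene is joined therefore matters, and not only which atoms it contains. No available evidence explains this step.

From the compounds shown here alone, whether a phenyl, furan-3-yl or pyridin-3-yl ring would give a similar number at this place stays open. So does whether a methyl group on the thiophen-3-yl ring would lower the number further.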